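From phenyl to 4-(trifluoromethyl)benzyl on compound 2

The source may hold more compounds than are shown below. What is called first, only, known or untested is meant among the compounds shown, and "the series" means these compounds.

In a functional assay on MDA-MB-231 cells (Homo sapiens) for inhibition, read by CCK-8 assay, with a stated time of 48 h (on this read-out higher numbers stand for weaker inhibition of growth and lower numbers for stronger inhibition of growth), compound 1 (`Cc1ccccc1Nc1nc(Nc2cc(Cl)ccn2)ncc1Cl`) gives 52400 nM as its value, and compound 2 (`CN1CCN(c2ccc(Nc3ncc(Cl)c(Nc4ccccc4)n3)nc2)CC1`) gives 37400 nM as its value. These two numbers lie within the usual scatter of each other, so the data do not separate compound 2 from compound 1. Compound 3 (`CN1CCN(c2ccc(Nc3ncc(Cl)c(NCc4ccc(C(F)(F)F)cc4)n3)nc2)CC1`) keeps the rest of compound 2 but carries 4-(trifluoromethyl)benzyl in place of phenyl on a nitrogen on an aromatic ring. Within the data shown here, no measured pair shows what a swap of this kind does, so the expectation is loose. In this assay a moderate step towards stronger inhibition of growth is expected, although a result within the scatter would be no surprise. The estimate means a 3.1-fold lower number from compound 2 to compound 3 (0.49 log units; beyond the scatter) as the expected step. Compound 3 is estimated at 12000 nM (expected range 2500 nM to 50000 nM).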

Compound 3, concentration for 50% growth inhibition: 19100 nM
For compound 3 the middle estimate is 1.6-fold (0.20 log units) below the measured one, within the range that was stated.
By their numbers in this assay, from the lowest: compounds 3, 2 and 1 (each within the scatter of the next, the first and the last beyond it).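

In this assay, the swap of phenyl for 4-(trifluoromethyl)benzyl gives a 2.0-fold lower number from compound 2 to compound 3 (0.29 log units; within the scatter) and so stays within the usual scatter, which means the data do not separate the two compounds. Among these compounds, this nitrogen therefore accepts a group of 11 heavy atoms in place of one of 6 with no clear change in the read-out, something the earlier compounds could not show. No measurement offered here accounts for this result.

The entering group differs from phenyl in two ways at once, the added carbon link and the trifluoromethyl, so this single pair cannot show what each does alone. Plain benzyl on the same nitrogen would tell these two apart, while a longer chain such as 2-phenylethyl or a saturated ring such as cyclohexyl would test how far this position can be pushed.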